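Swapping chloro for bromo on the shared core

The source may report more compounds than this note shows. Statements on the series, on what has been measured and on what is new or still open speak of the compounds shown alone.

Measured so far:
Compound 1 `COc1ccc(-c2cn3ccnc3c(-c3ccc4ncn(C5CCCCC5)c4c3)n2)cc1` gives 95.2% in a functional assay on PC-3 cells (Homo sapiens) for inhibition, read by sulforhodamine B assay, with a stated time of 48 h, tested at 10 uM; on this read-out lower numbers stand for less inhibition and higher numbers for more inhibition at the one concentration tested (going by the name of the read-out).
Compound 2 `Fc1ccc(-c2cn3ccnc3c(-c3ccc4ncn(C5CCCCC5)c4c3)n2)cc1` gives 53.6% in this assay.
Compound 3 `Clc1ccc(-c2cn3ccnc3c(-c3ccc4ncn(C5CCCCC5)c4c3)n2)cc1` gives 24.6% in this assay.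

Compound 3 stands lowest of these three numbers: its nearest neighbour is compound 2, and the gap a number 29 percentage points lower from compound 2 to compound 3 (beyond the scatter) lies beyond the scatter, while the gap to compound 1, a number 70.6 percentage points lower from compound 1 to compound 3 (beyond the scatter), is larger still. Compound 4 `Brc1ccc(-c2cn3ccnc3c(-c3ccc4ncn(C5CCCCC5)c4c3)n2)cc1` differs from compound 3 in one place: bromo in place of chloro on an aromatic carbon. Going by the values given here, no measured pair shows bromo against chloro, so the only steps that bear on it are the halogen-to-halogen step a number 29 percentage points lower from compound 2 to compound 3 (beyond the scatter), which was modest and downward, and the two steps away from methoxy, a number 41.6 percentage points lower from compound 1 to compound 2 (beyond the scatter) and a number 70.6 percentage points lower from compound 1 to compound 3 (beyond the scatter), both large and downward. One halogen swap is a thin basis, and compound 3 already sits low, leaving little room to fall. A small further drop, or no change beyond the scatter, is therefore expected in this assay. Compound 4 is estimated at 18%, with a range from 4% to 38%, which means an expected step of a number 6.6 percentage points lower from compound 3 to compound 4 (within the scatter).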

Compound 4, a percentage reported as inhibition, at one concentration (the size of the read-out at that concentration, not a potency): 42.4%
For compound 4 the middle estimate is 24.4 percentage points below the measured one; the whole stated range lies below it.
By their numbers in this assay, from the lowest: compound 3; then compound 4; then compound 2; then compound 1.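

In this assay, the order of the halogens at this position, para to a large group, turns out not to be a steady slide: bromo gives a rise over chloro (a number 17.8 percentage points higher from compound 3 to compound 4 (beyond the scatter)), so the fall seen from fluoro to chloro does not continue, and chloro is the low point of the three. Bromo does not get back to the fluoro level (a number 11.2 percentage points lower from compound 2 to compound 4 (beyond the scatter)), and methoxy still stands well above it (a number 52.8 percentage points lower from compound 1 to compound 4 (beyond the scatter)). Nothing measured here accounts for this uneven halogen order.

The compounds shown leave open whether iodo would extend the rise seen from chloro to bromo. They also leave open how a hydroxyl or an amine on the same aromatic carbon would compare with methoxy.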